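This account rests on a few compounds, and the source may have more. Where it says the series, first, only, none or still open, it means among the compounds named here.

Compound 3 `O=S(=O)(NCCCNCc1cccc(Cl)c1)c1cc(C(F)(F)F)cc(C(F)(F)F)c1` gives the highest number of the three measured compounds in a functional assay on HT-29 cells (Homo sapiens) for inhibition, read by MTT assay, with a stated time of 72 h; on this read-out lower numbers stand for stronger inhibition of growth and higher numbers for weaker inhibition of growth: compound 3 reaches 14000 nM. Compound 2 `O=S(=O)(NCCCNCc1ccc(Cl)c(C(F)(F)F)c1)c1cc(C(F)(F)F)cc(C(F)(F)F)c1` gives 11000 nM, and the gap a 1.3-fold higher number from compound 2 to compound 3 (0.10 log units; within the scatter) stays within the scatter. Compound 1 `O=S(=O)(NCCCNCc1ccc(Cl)c(Cl)c1)c1cc(C(F)(F)F)cc(C(F)(F)F)c1` gives 4700 nM, and the step of a 3.0-fold higher number from compound 1 to compound 3 (0.47 log units; beyond the scatter) lies beyond it. Compound 4 `O=S(=O)(NCCCNCc1ccc(Cl)cc1)c1cc(C(F)(F)F)cc(C(F)(F)F)c1` differs from compound 3 by 4-chlorophenyl in place of 3-chlorophenyl on a saturated chain carbon bound to an amine nitrogen. For the measured compounds named here, no measured step compares 3-chlorophenyl with 4-chlorophenyl directly; the steps of a 3.0-fold higher number from compound 1 to compound 3 (0.47 log units; beyond the scatter) and a 2.3-fold higher number from compound 1 to compound 2 (0.37 log units; beyond the scatter) show only that what sits on that phenyl moves the numbers modestly. The step in this assay is therefore expected to be small, a 1.4-fold lower number from compound 3 to compound 4 (0.15 log units; within the scatter), with either direction open. Compound 4 is estimated at 10000 nM, within 4000 nM to 25000 nM.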

Compound 4, concentration for 50% growth inhibition: 2800 nM
Beside the measured number, compound 4's estimate is 3.6-fold (0.55 log units) above it; measured number below the stated range.
By their numbers in this assay, from the lowest: compounds 4 and 1 (each within the scatter of the next); then compounds 2 and 3 (each within the scatter of the next).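

In this assay, for the compounds shown here, 4-chlorophenyl in place of 3-chlorophenyl gives a 5.0-fold lower number from compound 3 to compound 4 (0.70 log units; beyond the scatter), showing what the earlier compounds could not: the place of a single chloro on this phenyl alters the read-out beyond the scatter. Hydrogen in place of trifluoromethyl gives a 3.9-fold lower number from compound 2 to compound 4 (0.59 log units; beyond the scatter), so the added trifluoromethyl of compound 2 goes with weaker inhibition of growth. Hydrogen in place of chloro gives a 1.7-fold lower number from compound 1 to compound 4 (0.22 log units; within the scatter), so the second chloro of compound 1 makes no difference beyond the scatter. Nothing available explains these steps. As far as these compounds go, whether 4-methoxyphenyl or 4-fluorophenyl in place of 4-chlorophenyl, or a longer chain, would hold this level stays open.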